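Hydroxymethyl removal on the sulfur-linked alkyne chain

A few compounds are considered here, and "the series" means these few. Any claim that something is new, unique, unknown or untested is made for them only; others in the source may bear on it.

Measured so far in a functional assay on SW707 cells (Homo sapiens) for cytotoxicity, read by sulforhodamine B assay, with a stated time of 72 h; a lower number here means a stronger inhibitor, a higher number a weaker inhibitor:
compound 1 `OCC#CCSc1cnc2ccccc2c1SCC#CCBr`: 36.2 ug/mL
compound 2 `OCC#CCSc1cnc2ccccc2c1[Se]CC#CCO`: 26.6 ug/mL
compound 3 `C#CC[Se]c1c(SCC#CCO)cnc2ccccc12`: 3.8 ug/mL

Compound 2 gives the second highest of the three numbers. Its nearest neighbour is compound 1, and the step of a 1.4-fold lower number from compound 1 to compound 2 (0.13 log units; within the scatter) stays within the scatter, so nothing separates these two. Compound 3 sits well apart: the step of a 7.0-fold lower number from compound 2 to compound 3 (0.85 log units; beyond the scatter) is beyond the scatter, and from compound 1 the step of a 9.5-fold lower number from compound 1 to compound 3 (0.98 log units; beyond the scatter) points the same way.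

Compound 4 `C#CCSc1cnc2ccccc2c1[Se]CC#CCO` is the next entry. It differs from compound 2 by hydrogen in place of hydroxymethyl on a triple-bonded carbon, here on the chain carried by sulfur rather than on the one carried by selenium. Among the compounds with values here, the only step that bears on this directly is a 7.0-fold lower number from compound 2 to compound 3 (0.85 log units; beyond the scatter), the same change on the other chain, which lowered the number by a modest margin. Within the data shown here, compound 4 and compound 3 thus carry the same pair of chains, exchanged between the two positions, and no measured pair tells how much such an exchange matters.

On that basis a lowering of comparable size is expected for compound 4, a 4.8-fold lower number from compound 2 to compound 4 (0.68 log units; beyond the scatter). The estimate for compound 4 in this assay is 5.5 ug/mL, with a range from 2.2 ug/mL to 14 ug/mL.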

Compound 4, concentration for 50% inhibition: 3.3 ug/mL
Compound 4: middle estimate off by 1.7-fold (0.22 log units), on the high side; the range from low to high includes it.
By their numbers in this assay, from the lowest: compounds 4 and 3 (each within the scatter of the next); then compounds 2 and 1 (each within the scatter of the next).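

In this assay, within the data shown here, the same change on the chain carried by sulfur gives an 8.1-fold lower number from compound 2 to compound 4 (0.91 log units; beyond the scatter) and so has an effect on that chain as well; until now it had been seen only on the chain carried by selenium, as a 7.0-fold lower number from compound 2 to compound 3 (0.85 log units; beyond the scatter) and with hydrogen in place of hydroxymethyl on a triple-bonded carbon. Both steps start from compound 2, lie beyond the scatter and point the same way, so in this pair loss of one hydroxymethyl from either chain is enough to lower the number, with the other 4-hydroxybut-2-yn-1-yl chain still in place. Nothing available explains this change on either chain.

The compounds shown leave open what the core gives with propargyl on both chains, that is, whether the two removals add up or a single one already accounts for the whole lowering. Also open, as far as these compounds go, is how an aminomethyl group, a carboxylic acid or a longer chain would read in place of hydroxymethyl on the triple-bonded carbon.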